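The source may report more compounds than this note shows. Statements on the series, on what has been measured and on what is new or still open speak of the compounds shown alone.

Measured compounds: compound 1 `N#Cc1c(NCc2ccccc2)sc2c1CCN(C(=O)c1ccccc1)C2` gives 2820 nM in a functional assay on Chem-3 cells for antagonist activity at metabotropic glutamate receptor 1 (Homo sapiens), read by fluorescence and calcium flux; on this read-out lower numbers stand for stronger inhibition and higher numbers for weaker inhibition; compound 2 `N#Cc1c(NCc2ccc(F)cc2)sc2c1CCN(C(=O)c1ccccc1)C2` gives 1810 nM; compound 3 `N#Cc1c(NCc2ccc(F)cc2)sc2c1CCN(C(=O)c1ccc(F)cc1)C2` gives "not determined" (no result reported), so no number is reported for it.

Compound 2 has the lowest of the two numbers available, though a 1.6-fold lower number from compound 1 to compound 2 (0.19 log units; within the scatter) is within the scatter, so compound 1 and compound 2 cannot be ordered. The change to compound 4 `N#Cc1c(NCc2cccc(F)c2)sc2c1CCN(C(=O)c1ccccc1)C2` is 3-fluorophenyl in place of 4-fluorophenyl on a saturated chain carbon bound to a nitrogen on an aromatic ring. Within the data shown here, no measured step moves the fluorine around this ring; the only step on this ring, from compound 1 to compound 2, stays within the scatter. Therefore the expectation for a 1.1-fold higher number from compound 2 to compound 4 (0.04 log units; within the scatter) is no step beyond the scatter, in either direction. Compound 4 is estimated at 2000 nM, with a range of 800 nM to 5000 nM.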

Compound 4, half-maximal inhibitory concentration: 5310 nM
For compound 4 the middle estimate is 2.7-fold (0.42 log units) below the measured one; the measured number lies above the stated range.
By their numbers in this assay, from the lowest: compounds 2, 1 and 4 (each within the scatter of the next, the first and the last beyond it).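

In this assay, among these compounds, moving the fluorine registers for the first time: 4-fluorobenzyl to 3-fluorobenzyl gives a 2.9-fold higher number from compound 2 to compound 4 (0.47 log units; beyond the scatter), a modest step beyond the scatter. Set against the unsubstituted benzyl, the 3-fluorobenzyl group gives a 1.9-fold higher number from compound 1 to compound 4 (0.27 log units; within the scatter), within the scatter, so the two fluorinated isomers separate from each other but neither separates from compound 1. No evidence at hand bears on this gap. Going by these compounds, whether a chloro or methoxy group in place of the fluorine shows the same gap remains open, as does the outcome with a longer chain in place of the benzyl group.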